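Swapping dimethylamino for diethylamino at the end of a propyl chain

The compounds below may be only part of what the source reports. "The series", "measured", "known", "first", "only" and "open" are said of these compounds alone.

Compound 1 `CN(C)CCn1c(N)c(-c2nc3cc(Cl)ccc3[nH]2)c2nc(C#N)c(C#N)nc21`: > 50000 nM, a limit of the assay and not a number
Compound 2 `CN(C)CCCn1c(N)c(-c2nc3cc(Cl)ccc3[nH]2)c2nc(C#N)c(C#N)nc21`: 2930 nM

Within the data shown here, in a functional assay on HL-60 cells (Homo sapiens) for antiproliferative activity, read by MTT assay, with a stated time of 48 h (on this read-out higher numbers stand for weaker inhibition and lower numbers for stronger inhibition), compound 2 gives 2930 nM, the only actual number so far. Compound 3 `CCN(CC)CCCn1c(N)c(-c2nc3cc(Cl)ccc3[nH]2)c2nc(C#N)c(C#N)nc21` has diethylamino in place of dimethylamino on a saturated chain carbon, three bonds along the chain from an aromatic nitrogen. Among the measured compounds shown here, the sole measured step, an at least 17-fold lower number from compound 1 to compound 2 (1.23 log units; beyond the scatter), changed the chain and left the end group alone, so it bears only indirectly on compound 3, which keeps the chain of compound 2. No change beyond the scatter is therefore expected in this assay. The expected step is a 1.2-fold lower number from compound 2 to compound 3 (0.07 log units; within the scatter). Compound 3 is estimated at 2500 nM, within a range of 900 nM to 7000 nM.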

Compound 3, half-maximal inhibitory concentration: 3470 nM
For compound 3 the middle estimate is 1.4-fold (0.14 log units) below the measured one; measured number inside the range.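

In this assay, moving from dimethylamino to diethylamino at the end of the propyl chain leaves activity unchanged within the scatter (a 1.2-fold higher number from compound 2 to compound 3 (0.07 log units; within the scatter)). The large gap to the shorter chain also remains with the new end group (an at least 14-fold lower number from compound 1 to compound 3 (1.15 log units; beyond the scatter)). That step is only a bound, because compound 1 stands at a limit and not a number: the limit of > 50000 nM in this assay, at which 1 of the 3 values shown sits.

From the compounds shown here alone, it remains open whether a cyclic amine such as piperidine or morpholine would keep this activity at the end of the propyl chain. A longer chain, such as 4-(dimethylamino)butyl, also remains untested among the compounds shown.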